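The source may report more compounds than this note shows. Statements on the series, on what has been measured and on what is new or still open speak of the compounds shown alone.

Compound 1 `Nc1scc(CN2CCN(c3cccc(C(F)(F)F)c3)CC2)c1C(=O)c1ccc(Cl)cc1`: -72%
Compound 2 `Nc1scc(CN2CCN(c3cccnc3)CC2)c1C(=O)c1ccc(Cl)cc1`: -2.7%
Compound 3 `Nc1scc(CN2CCN(c3ccc(F)cc3F)CC2)c1C(=O)c1ccc(Cl)cc1`: -66%

In a functional assay on CHO cells with adenosine receptor A1 (Homo sapiens) as the target, read by cAMP accumulation and immunoassay, with a stated time of 6 min, tested at 1 uM (on this read-out lower numbers stand for a stronger effect and higher numbers for a weaker effect at the one concentration tested), compound 1 gives the lowest of the three numbers shown, though compound 3 sits within the scatter of it and only compound 2 lies far away. Compound 4 `Nc1scc(CN2CCN(c3cccc(F)c3F)CC2)c1C(=O)c1ccc(Cl)cc1` differs from compound 1 in one place: 2,3-difluorophenyl in place of 3-(trifluoromethyl)phenyl on an amine nitrogen in a ring. Among the compounds with values here, two measured steps bear on this. The step of a number 6 percentage points higher from compound 1 to compound 3 (within the scatter) also brought in a difluorophenyl and stayed within the scatter, whereas a number 69.3 percentage points higher from compound 1 to compound 2 (beyond the scatter) brought in a pyridin-3-yl and was large. The change to compound 4 resembles the former, so no step beyond the scatter is expected: a number 6 percentage points higher from compound 1 to compound 4 (within the scatter). Compound 4 is therefore estimated at -66%, within a range of -82% to -45%.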

Compound 4, a percentage reported as activity, at one concentration (the size of the read-out at that concentration, not a potency): -66%
The estimate for compound 4 equals the measured number at the digits printed; the range from low to high includes it.
By their numbers in this assay, from the lowest: compounds 1, 3 and 4 (each within the scatter of the next); then compound 2.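

In this assay the change from 3-(trifluoromethyl)phenyl to 2,3-difluorophenyl gives a number 6 percentage points higher from compound 1 to compound 4 (within the scatter), and the change from 2,4-difluorophenyl to 2,3-difluorophenyl gives no change at the digits printed from compound 3 to compound 4 (within the scatter), so the two difluorophenyl groups on this ring nitrogen read alike. The pyridin-3-yl group stands apart again, with a number 63.3 percentage points lower from compound 2 to compound 4 (beyond the scatter). Nothing measured here explains this difference between the pyridin-3-yl group and the other groups.

As far as these compounds go, whether a phenyl ring with one fluorine, a methoxy group or an amine would keep this effect remains open.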